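The compounds below may be only part of what the source reports. "The series", "measured", "known", "first", "only" and "open" are said of these compounds alone.

The measured compounds and their values in an assay on CHO cells for displacement of a labelled ligand from adenosine receptor A1 (Homo sapiens), read by scintillation counting, with a stated time of 1 h, tested at 1 uM; a higher number here means more inhibition at the concentration tested (going by the name of the read-out), a lower number less inhibition:

compound 1, `Nc1ncc(-c2cccc(F)c2)c(-c2ccccc2)n1`: 63%
compound 2, `Nc1ncc(-c2cccc(Cl)c2)c(-c2ccccc2)n1`: > 80%
compound 3, `COc1ccc(-c2cnc(N)nc2-c2ccccc2)cc1Cl`: > 80%

Compound 2 stands at the top of what this assay reports: its value is a limit, not a number, and (the limit of > 80% in this assay, at which 2 of the 3 values shown sit). Compound 3 likewise gives only a limit. Going by the values given here, compound 1 is the only one with a plain number, and the step of a number at least 17 percentage points higher from compound 1 to compound 2 (beyond the scatter) shows the chloro compound reading higher than the fluoro compound. The step that the two limits leave unreadable from compound 2 to compound 3 runs between two limits and so cannot be sized.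

Compound 4, `CCCCNc1ncc(-c2cccc(Cl)c2)c(-c2ccccc2)n1`, has not yet been measured. It differs from compound 2 in one place: butyl in place of hydrogen on a nitrogen on an aromatic ring. Neither measured step bears on this change, since both concern the substituted aromatic ring, whereas here the amino group itself is changed. Without a comparable step, the direction is uncertain, and a moderate fall from the limit is expected. Compound 4 is estimated to give 55% in this assay, between 20% and 85%. This estimate means an expected step of a number at least 25 percentage points lower from compound 2 to compound 4 (beyond the scatter).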

Compound 4, a percentage reported as inhibition, at one concentration (the size of the read-out at that concentration, not a potency): 56%
Compound 4: the middle estimate sits 1 percentage points below what was measured, within the range that was stated.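

The earlier compounds changed only the substituted aromatic ring, whereas this change is the first shown at the amino group: going from amino to butylamino gives, in this assay, a number at least 24 percentage points lower from compound 2 to compound 4 (beyond the scatter). Compound 4 still gives 56%, so with a butyl group on this nitrogen the inhibition is lower but has not gone. The true size of the fall stays unknown, because compound 2 gives only a limit: the limit of > 80% in this assay, at which 2 of the 4 values shown sit.

Going by these compounds, what a smaller group such as methyl, a longer chain such as hexyl or a carboxylic acid on this nitrogen would give stays open, so a single butyl step shows no trend with chain length. On these data alone, it is also open whether butyl on the same nitrogen would lower the reading of compound 1 in the same way.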